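Working notes: nitrogen substituent step from compound 2

The source may hold more compounds than are shown below. What is called first, only, known or untested is meant among the compounds shown, and "the series" means these compounds.

Measured so far in a functional assay on HepG2 cells (Homo sapiens) for cytotoxicity, read by MTT assay, with a stated time of 24 h; on this read-out higher numbers stand for weaker inhibition and lower numbers for stronger inhibition
compound 1 `CN1C/C(=C\c2cccnc2)C(=O)/C(=C/c2ccccc2F)C1` gives 4810 nM
compound 2 `CN1C/C(=C\c2ccncc2)C(=O)/C(=C/c2ccccc2F)C1` gives 4600 nM
compound 3 `CN1C/C(=C\c2ccncc2)C(=O)/C(=C/c2ccccc2C(F)(F)F)C1` gives 3300 nM

Compound 2 lies within the scatter of both other compounds, so the three sit at one level. Compound 4 `O=C1/C(=C/c2ccncc2)CN(S(=O)(=O)c2ccccc2)C/C1=C\c1ccccc1F` has phenylsulfonyl in place of methyl on an amine nitrogen in a ring. The measured steps of a 1.0-fold lower number from compound 1 to compound 2 (0.02 log units; within the scatter) and a 1.4-fold lower number from compound 2 to compound 3 (0.14 log units; within the scatter) both stay within the scatter, and both change other places. Going by the values given here, no measured compound varies this nitrogen substituent, so the data give no direction, and no step beyond the scatter is expected, though with wide uncertainty. The expected step is a 1.2-fold lower number from compound 2 to compound 4 (0.06 log units; within the scatter). Compound 4 is estimated at 4000 nM, with an expected range of 1200 nM to 12000 nM.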

Compound 4, half-maximal inhibitory concentration: 5800 nM
The estimate for compound 4 lay 1.5-fold (0.16 log units) below the measured number; the range from low to high includes it.
By their numbers in this assay, from the lowest: compounds 3, 2, 1 and 4 (each within the scatter of the next).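

Phenylsulfonyl in place of methyl on an amine nitrogen in a ring is the first change read at this position, and in this assay it gives a 1.3-fold higher number from compound 2 to compound 4 (0.10 log units; within the scatter). Going by these compounds alone, replacing the single carbon of methyl with 9 heavy atoms, including an aromatic ring and 2 hydrogen-bond acceptors, therefore leaves the number at the level of the earlier compounds. No evidence on the origin of this result is available.

On these data alone, whether a benzyl or acetyl group on this nitrogen stays at that level remains open. Also open, as far as these compounds go, is whether phenylsulfonyl behaves the same way alongside trifluoromethyl in place of fluoro.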